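The source may hold more compounds than are shown below. What is called first, only, known or untested is meant among the compounds shown, and "the series" means these compounds.

Working notes on the series in a functional assay on LNCaP cells (Homo sapiens) for cytotoxicity, read by MTT assay, with a stated time of 24 h; on this read-out higher numbers stand for an effect only at larger amounts of compound and lower numbers for an effect already at smaller amounts. Compound 1 `Fc1ccc(N2CCN(CCN3CCN(c4ccc(F)cc4)CC3)CC2)cc1` gives 71200 nM, compound 2 `O=[N+]([O-])c1ccc(N2CCN(CCN3CCN(c4ccc(F)cc4)CC3)CC2)cc1` gives 77900 nM, and compound 3 `COc1ccccc1N1CCN(CCN2CCN(c3ccc(F)cc3)CC2)CC1` gives 78700 nM. Compound 3 therefore stands level with the other two, within the scatter.

Compound 4 `Fc1ccc(N2CCN(CCN3CCN(c4ccccc4F)CC3)CC2)cc1` has fluoro in place of methoxy on an aromatic carbon, ortho to a large group, the same difference reading 2-methoxyphenyl to 2-fluorophenyl: fluoro in place of methoxy on an aromatic carbon. Going by the values given here, no measured compound carries 2-fluorophenyl, so the evidence is indirect.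

Among the compounds with values here, three measured steps bear on the change, each altering one aromatic group at an end of the shared core: a 1.1-fold higher number from compound 1 to compound 2 (0.04 log units; within the scatter), a 1.1-fold higher number from compound 1 to compound 3 (0.04 log units; within the scatter) and a 1.0-fold higher number from compound 2 to compound 3 (0.00 log units; within the scatter). All three lie within the scatter, including the two that remove or introduce 2-methoxyphenyl. On these steps, no change beyond the scatter is expected in this assay, and no direction can be favoured.

The estimated step is a 1.0-fold lower number from compound 3 to compound 4 (0.02 log units; within the scatter). For compound 4 the expected value is 75000 nM, with an expected range of 48000 nM to 115000 nM.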

Compound 4, half-maximal effective concentration: 68000 nM
For compound 4 the middle estimate is 1.1-fold (0.04 log units) above the measured one, within the range that was stated.
By their numbers in this assay, from the lowest: compounds 4, 1, 2 and 3 (each within the scatter of the next).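

In this assay, going by these compounds alone, the first direct reading of a change at this position, on an aromatic carbon ortho to a large group, is a 1.2-fold lower number from compound 3 to compound 4 (0.06 log units; within the scatter) for fluoro in place of methoxy, which leaves the number within the scatter. Compound 4 also stays within the scatter of the compounds with a different aromatic group at that end of the shared core, with a 1.1-fold lower number from compound 2 to compound 4 (0.06 log units; within the scatter) for 2-fluorophenyl in place of 4-nitrophenyl and a 1.0-fold lower number from compound 1 to compound 4 (0.02 log units; within the scatter) for 2-fluorophenyl in place of 4-fluorophenyl. No supporting measurement accounts for this flat result.

Still open, on these data alone, is whether any group at this position would shift the number beyond the scatter, for example an amine or a carboxylic acid in place of fluoro. The compounds shown also leave open whether a longer chain within the shared core would do so.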